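The compounds below may be only part of what the source reports. "The series", "measured", "known", "first", "only" and "open" are said of these compounds alone.

Three compounds built on one shared core have been examined in an ADME assay on HEK293 cells (Homo sapiens) for cytotoxicity, with a stated time of 72 h; a lower number here means that less compound is needed, a higher number that more compound is needed for the effect. Compound 1 `Cc1cc(NC(=O)Nc2ccc(C(=O)O)cc2)c2ccccc2n1` carries a carboxy group, and in this assay compound 1 gives > 25000 nM, which is a limit of the assay rather than a number. Compound 2 `Cc1cc(NC(=O)Nc2ccc(Cl)cc2)c2ccccc2n1` has chloro in that place, and in this assay compound 2 gives > 25000 nM, again a limit. Compound 3 `Cc1cc(NC(=O)Nc2ccc(C(C)(C)C)cc2)c2ccccc2n1` bears tert-butyl, and in this assay compound 3 gives > 25000 nM, also a limit. The steps a step that the two limits leave unreadable from compound 1 to compound 2, a step that the two limits leave unreadable from compound 1 to compound 3 and a step that the two limits leave unreadable from compound 2 to compound 3 therefore cannot be sized, because of the limit of > 25000 nM in this assay, at which 3 of the 3 values shown sit. Compound 3 thus stands at the limit with both other compounds, and nothing in the numbers sets it apart from them.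

Compound 4 `CCc1ccc(NC(=O)Nc2cc(C)nc3ccccc23)cc1` has not yet been measured. It differs from compound 3 in a single place: ethyl in place of tert-butyl on an aromatic carbon. Going by the values given here, no measured step bears directly on the exchange of tert-butyl for ethyl; the three steps at hand all change the same position and all end at the limit, so none gives a readable size. Among the compounds with values here, with every value so far sitting at the limit, the expected step is a step that the limit leaves unreadable from compound 3 to compound 4, none beyond the scatter. Compound 4 is accordingly estimated at 35000 nM, and most likely the assay will again report only a limit.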

Compound 4, half-maximal effective concentration: 16000 nM
Compound 4: middle estimate off by 2.2-fold (0.34 log units), on the high side, outside the stated range (below it).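

In this assay, going by these compounds alone, this position gives a number rather than a limit for the first time: with ethyl on the aromatic carbon, 2 heavy atoms stand where tert-butyl had 4, and the reading of compound 4 comes into the range of the assay. The exchange of tert-butyl for ethyl gives an at least 1.5-fold lower number from compound 3 to compound 4 (0.19 log units; that floor lies within the scatter), while the exchanges from chloro and from carboxy give an at least 1.5-fold lower number from compound 2 to compound 4 (0.19 log units; that floor lies within the scatter) and an at least 1.5-fold lower number from compound 1 to compound 4 (0.19 log units; that floor lies within the scatter). Each of these is a floor and not a size, so the result does not establish how far compound 4 stands from the other three, and the steps among those three still cannot be read: the limit of > 25000 nM in this assay, at which 3 of the 4 values shown sit.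

The compounds shown leave open whether a number at this position belongs to ethyl alone or would also appear with methyl, with a longer chain such as propyl, or with an amine. They also leave open whether any of compounds 1, 2 and 3 differ from one another at all in this assay.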